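Bromo to fluoro exchange on the hydroxy-bearing ring

A few compounds are considered here, and "the series" means these few. Any claim that something is new, unique, unknown or untested is made for them only; others in the source may bear on it.

Measured compounds:
compound 1 `O=C(Nc1ccc(C(F)(F)F)cc1)c1cc(F)ccc1O` gives 580 nM
compound 2 `O=C(Nc1ccc(C(F)(F)F)cc1)c1ccc(Br)cc1O` gives 500 nM
compound 3 `O=C(Nc1ccc(C(F)(F)F)cc1)c1cc(Br)ccc1O` gives 620 nM

All three were read in a functional assay on Jurkat cells (Homo sapiens) for cytotoxicity, read by luminescence and CellTiter-Glo, with a stated time of 3 days; a higher number here means a weaker inhibitor, a lower number a stronger inhibitor. The three values lie close together, and none of the differences among them is beyond the scatter, so no order of potency is claimed. Compound 2 and compound 3 share the same atoms joined differently; the difference between the two cores is not broken down here, and their values in this assay show only that they sit within the scatter of each other.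

One change has been seen once: fluoro in place of bromo on an aromatic carbon, which gave a 1.1-fold lower number from compound 3 to compound 1 (0.03 log units; within the scatter), a step within the scatter.

Compound 4 `O=C(Nc1ccc(C(F)(F)F)cc1)c1ccc(F)cc1O` is not yet measured. It is made from compound 2 by fluoro in place of bromo on an aromatic carbon. The surroundings of the place differ from those in the step from compound 3 to compound 1: there the carbon was meta to a large group and para to a hydroxy group, here it is meta to a hydroxy group and para to a large group, so this is the same kind of change, not the same change. The expected step is a 1.1-fold lower number from compound 2 to compound 4 (0.03 log units; within the scatter), a step within the scatter, and that expectation rests on compound 3, whose step a 1.1-fold lower number from compound 3 to compound 1 (0.03 log units; within the scatter) was within the scatter. The estimate for compound 4 in this assay is 470 nM, expected to fall between 240 nM and 950 nM.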

Compound 4, half-maximal inhibitory concentration: 800 nM
For compound 4 the middle estimate is 1.7-fold (0.23 log units) below the measured one; measured number inside the range.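

On the core of compound 2, fluoro in place of bromo on an aromatic carbon gives a 1.6-fold higher number from compound 2 to compound 4 (0.20 log units; within the scatter) in this assay. Set beside the earlier step, the exchange does not come apart between the two cores: the same change on two cores in this assay, a 1.1-fold lower number (0.03 log units; within the scatter) from compound 3 to compound 1 and a 1.6-fold higher number (0.20 log units; within the scatter) from compound 2 to compound 4, 1.7-fold (0.23 log units) apart, within the scatter of two such steps. For the compounds shown here, this supports carrying the change from one of these cores to the other as a step that stays within the scatter, with the two opposite directions carrying no weight, but it does not show that the change is without effect in general or that the two cores respond in the same way, as only one pair on each core stands behind it, with the exchanged carbon in a different place on each.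

The compounds shown leave open whether a group of another kind on this carbon, such as an amine, a carboxylic acid or a longer chain, would give a step beyond the scatter in this assay. Also open, going by these compounds, is how far the values depend on the hydroxy group and on the trifluoromethyl group, both of which stand unchanged in all four compounds.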